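A few compounds are considered here, and "the series" means these few. Any claim that something is new, unique, unknown or untested is made for them only; others in the source may bear on it.

Among the compounds with values here, in a functional assay on the whole organism with Mus musculus as the target (on this read-out higher numbers stand for an effect only at larger amounts of compound and lower numbers for an effect already at smaller amounts), compound 1 `Cc1c(C)c2c(c(C)c1N)CC(C)(C)O2` gives 7.8 mg/kg, the lower of the only two numbers available. The other number belongs to compound 2 `Cc1c(C)c2c(c(C)c1N)CC(C)(CCN1CCCCC1)O2`, which gives 18.4 mg/kg. That comparison is a 2.4-fold higher number from compound 1 to compound 2 (0.37 log units; beyond the scatter), and it comes from placing (piperidin-1-yl)methyl on a saturated chain carbon.

Compound 3 `Cc1c(C)c2c(c(C)c1N)C(c1cccnc1)C(C)(C)O2` instead carries pyridin-3-yl in place of hydrogen on a saturated ring carbon, (pyridin-3-yl in place of hydrogen on a saturated ring carbon). Within the data shown here, no measured step changes this ring carbon or adds this group, so the evidence is thin. The closest guide is the modest rise seen for compound 2 with a 2.4-fold higher number from compound 1 to compound 2 (0.37 log units; beyond the scatter), where a large group was also added to compound 1. A similar modest rise is therefore expected, though a step within the scatter remains possible. The expected change is a 1.7-fold higher number from compound 1 to compound 3 (0.22 log units; within the scatter). For compound 3 the estimated value is 13 mg/kg, with an expected range of 4.5 mg/kg to 38 mg/kg.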

Compound 3, dose for 50% inhibition: 32.1 mg/kg
Compound 3: middle estimate off by 2.5-fold (0.39 log units), on the low side; measured number inside the range.
By their numbers in this assay, from the lowest: compound 1; then compounds 2 and 3 (each within the scatter of the next).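

The saturated ring carbon two ring bonds from the ring oxygen now has its first reading: in this assay, replacing hydrogen there with pyridin-3-yl gives a 4.1-fold higher number from compound 1 to compound 3 (0.61 log units; beyond the scatter), so a larger dose is needed for the same effect. This is a second place where an added group raises the number, after the earlier step at the saturated chain carbon, and hydrogen at the ring carbon remains the better of the two options tested there. Nothing shown gives a cause for this rise.

A plain phenyl ring at this ring carbon could show whether the ring nitrogen of pyridin-3-yl matters to the result. From the compounds shown here alone, it also remains open whether something much smaller here, such as a hydroxyl group or a primary amine, would leave the number close to that of compound 1.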